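Methyl for Hydrogen on the Phenyl of Compound 3

A few compounds are considered here, and "the series" means these few. Any claim that something is new, unique, unknown or untested is made for them only; others in the source may bear on it.

Compound 1 `Cc1nnc(SCC(=O)N/N=c2/scc(-c3ccc([N+](=O)[O-])cc3)n2-c2ccccc2)s1`: 177 ug/mL
Compound 2 `Cc1ccc(-c2cs/c(=N/NC(=O)CSc3nncn3C)n2-c2ccccc2)cc1`: 130 ug/mL
Compound 3 `Cc1nnc(SCC(=O)N/N=c2/scc(-c3ccccc3)n2-c2ccccc2)s1`: 197 ug/mL

These three compounds were tested in an ADME assay on NIH3T3 cells (Mus musculus) for cytotoxicity, read by MTT assay, with a stated time of 24 h; a lower number here means a stronger inhibitor, a higher number a weaker inhibitor. Compound 3 gives 197 ug/mL, and the values of compound 1 and compound 2 both lie within the usual scatter of that number, so no order among the three can be read. Compound 4 `Cc1ccc(-c2cs/c(=N/NC(=O)CSc3nnc(C)s3)n2-c2ccccc2)cc1` has not yet been measured. It differs from compound 3 in one place: methyl in place of hydrogen on an aromatic carbon. Within the data shown here, no measured step swaps hydrogen for methyl on this ring; the only single-site step seen, a 1.1-fold higher number from compound 1 to compound 3 (0.05 log units; within the scatter), altered the same ring without moving the number beyond the scatter. For compound 4 the expected step is a 1.2-fold lower number from compound 3 to compound 4 (0.06 log units; within the scatter). Compound 4 is therefore estimated at 170 ug/mL, with a range from 100 ug/mL to 300 ug/mL.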

Compound 4, half-maximal inhibitory concentration: 373 ug/mL
Beside the measured number, compound 4's estimate is 2.2-fold (0.34 log units) below it, and the stated range ends below it.
By their numbers in this assay, from the lowest: compounds 2, 1, 3 and 4 (each within the scatter of the next, the first and the last beyond it).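

Going from phenyl to 4-methylphenyl gives a 1.9-fold higher number from compound 3 to compound 4 (0.28 log units; within the scatter) in this assay, so methyl alone shifts the number no further than the scatter. Against nitro on the same aromatic carbon, methyl gives a 2.1-fold higher number from compound 1 to compound 4 (0.32 log units; beyond the scatter) and so shows the first modest step at this position. Changing the group on the sulfur to 5-methyl-1,3,4-thiadiazol-2-yl from 4-methyl-4H-1,2,4-triazol-3-yl gives a 2.9-fold higher number from compound 2 to compound 4 (0.46 log units; beyond the scatter) and shows that this second site can also move the number.

No measurement here explains these steps. As far as these compounds go, how an amine or a carboxylic acid on that aromatic carbon would read stays open.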